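The compounds below may be only part of what the source reports. "The series", "measured", "known", "first", "only" and "open" are said of these compounds alone.

Three compounds share one core, a long chain bound through an amide to a five-membered ring with a nitrogen and a sulfur, and differ only in the group on a saturated ring carbon. Compound 1 `CCCCCCCCCCCCCCCCCCNC(=O)[C@H]1CSC(Cc2ccccc2)N1` carries a benzyl group there and in a functional assay on TSU-Pr1 cells for antiproliferative activity against TSU (Homo sapiens), read by sulforhodamine B assay (a higher number here means a weaker inhibitor, a lower number a stronger inhibitor), compound 1 gives 11200 nM. Compound 2 `CCCCCCCCCCCCCCCCCCNC(=O)[C@H]1CSC(c2cccnc2)N1` carries a pyridin-3-yl group and in this assay compound 2 gives 7800 nM. Compound 3 `CCCCCCCCCCCCCCCCCCNC(=O)[C@H]1CSC(c2cccc(O)c2)N1` carries a 3-hydroxyphenyl group and in this assay compound 3 gives 4000 nM. Among these three numbers compound 3 stands at the low end: the step of a 2.8-fold lower number from compound 1 to compound 3 (0.45 log units; beyond the scatter) is beyond the scatter, while the step of a 2.0-fold lower number from compound 2 to compound 3 (0.29 log units; within the scatter) and the step of a 1.4-fold lower number from compound 1 to compound 2 (0.16 log units; within the scatter) are not.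

Compound 4 `CCCCCCCCCCCCCCCCCCNC(=O)[C@H]1CSC(c2ccc(Br)cc2)N1` differs from compound 3 in this way: 4-bromophenyl in place of 3-hydroxyphenyl on a saturated ring carbon. The three measured steps all exchange one aromatic group for another at the same saturated ring carbon, and none moved the number by more than a modest amount, with two of the three inside the scatter. On that basis the swap to 4-bromophenyl is expected to give a step of at most modest size in this assay, more likely toward a higher number than a lower one, so compound 4 is estimated at 7000 nM, with a range from 3000 nM to 16000 nM, which would mean an expected step of a 1.8-fold higher number from compound 3 to compound 4 (0.24 log units; within the scatter).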

Compound 4, half-maximal inhibitory concentration: 18300 nM
Beside the measured number, compound 4's estimate is 2.6-fold (0.42 log units) below it; measured number above the stated range.
By their numbers in this assay, from the lowest: compounds 3, 2, 1 and 4 (each within the scatter of the next, the first and the last beyond it).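

In this assay the step of a 4.6-fold higher number from compound 3 to compound 4 (0.66 log units; beyond the scatter) is the largest seen so far at this saturated ring carbon and the step of a 2.3-fold higher number from compound 2 to compound 4 (0.37 log units; beyond the scatter) is also beyond the scatter, while the step of a 1.6-fold higher number from compound 1 to compound 4 (0.21 log units; within the scatter) stays within it. Since 3-hydroxyphenyl and 4-bromophenyl have the same heavy-atom count and the same kind of aromatic ring, this position clearly distinguishes between two groups that match on those counts, so those counts alone do not set the number here. The change also removes the hydrogen-bond donor and acceptor of 3-hydroxyphenyl, but nothing available here shows why the number rises.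

The swap changes both the atom on the aromatic ring and its place on that ring, so this one step cannot show which of the two matters, and 3-bromophenyl and 4-hydroxyphenyl are the groups that would separate them. As far as these compounds go, it also remains open how this position would respond to a group with a nitrogen on the aromatic ring, such as 3-aminophenyl, or to a carboxylic acid there.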